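The source may report more compounds than this note shows. Statements on the series, on what has been measured and on what is new or still open speak of the compounds shown alone.

Working notes on the series in a functional assay on HCT-116 cells (Homo sapiens) for antiproliferative activity, read by MTT assay, with a stated time of 24 h; on this read-out higher numbers stand for weaker inhibition and lower numbers for stronger inhibition. Compound 1 `COc1cccc(C(=O)Oc2ccc3c(=O)c(-c4cc(OC)c(OC)cc4OC)coc3c2)c1` is reported at > 10000 nM, and this is a limit of the assay, not a number. Compound 2 `COc1cc(OC)c(-c2coc3cc(OCc4ccc(F)cc4)ccc3c2=O)cc1OC` gives 950 nM. Compound 3 `COc1cc(OC)c(-c2coc3cc(OCc4ccc(Br)cc4)ccc3c2=O)cc1OC` gives 1980 nM, the higher of the two actual numbers, with compound 2 as its nearest neighbour.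

Compound 4 `COc1cc(OC)c(-c2coc3cc(OCc4ccc(Cl)cc4)ccc3c2=O)cc1OC` differs from compound 3 by a single change: chloro in place of bromo on an aromatic carbon. That is, chloro in place of bromo on an aromatic carbon, para to a large group.

The measured step closest to this change is the other halogen swap, a 2.1-fold higher number from compound 2 to compound 3 (0.32 log units; beyond the scatter), which is modest. The two remaining steps, an at least 10-fold lower number from compound 1 to compound 2 (1.02 log units; beyond the scatter) and an at least 5.0-fold lower number from compound 1 to compound 3 (0.70 log units; beyond the scatter), are larger, but they replace (3-methoxyphenyl)carbonyl with a benzyl group and say little about a swap of one halogen for another.

Compound 4 is therefore expected to fall near the two halogen values, given a 2.1-fold higher number from compound 2 to compound 3 (0.32 log units; beyond the scatter). A small move towards a lower number is expected in this assay, probably not beyond the scatter. The expected step is a 1.4-fold lower number from compound 3 to compound 4 (0.15 log units; within the scatter). The estimate for compound 4 is 1400 nM, with an estimated range of 750 nM to 2600 nM.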

Compound 4, half-maximal inhibitory concentration: 4450 nM
The estimate for compound 4 lay 3.2-fold (0.50 log units) below the measured number, outside the stated range (above it).
By their numbers in this assay, from the lowest: compound 2; then compound 3; then compound 4. At a limit, above all of these: compound 1.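

In this assay, the chloro compound does not fall inside the span set by the fluoro and bromo compounds: the result is a 2.2-fold higher number from compound 3 to compound 4 (0.35 log units; beyond the scatter), and a 4.7-fold higher number from compound 2 to compound 4 (0.67 log units; beyond the scatter). On this aromatic carbon, para to a large group, the numbers therefore do not follow the halogen sequence fluoro, chloro, bromo, and compound 4 is the one that goes against it, so the single step from compound 2 to compound 3 could not have shown how a third halogen would read. Compound 1 is a limit of the assay and not a number, so an at least 2.2-fold lower number from compound 1 to compound 4 (0.35 log units; beyond the scatter) gives only a bound, and this is the smallest such bound among the benzyl compounds: the limit of > 10000 nM in this assay, at which 1 of the 4 values shown sits.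

The compounds shown leave open whether this uneven reading belongs to the halogens alone or extends to other groups on the same aromatic carbon, such as a methoxy group, an amine or a carboxylic acid. They also leave open how an unsubstituted benzyl group would read, so the three halogen values still lack a reference on the shared core.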